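The source may hold more compounds than are shown below. What is called first, only, known or untested is meant among the compounds shown, and "the series" means these compounds.

Measured so far:
compound 1, `O=C(/C=C/c1ccc(Cl)cc1Cl)c1ccccc1`, 12000 nM
compound 2, `CCC(/C=C(\COC(C)=O)C(=O)c1ccccc1)CC`, 77000 nM

Of the compounds shown here, two have been measured in a functional assay on SW1573 cells (Homo sapiens) for inhibition, read by sulforhodamine B assay, with a stated time of 48 h; on this read-out lower numbers stand for stronger inhibition of growth and higher numbers for weaker inhibition of growth. Compound 1 gives 12000 nM, and compound 2 gives 77000 nM. Compound 2 thus stands at the highest of the two numbers, the weaker of the pair, and its gap to compound 1 lies beyond the usual scatter of this assay.

The next compound, compound 3, `CC(=O)OC/C(=C\c1ccccc1Br)C(=O)c1ccccc1`, differs from compound 2 in one place: 2-bromophenyl in place of pentan-3-yl on a double-bonded chain carbon bound to a double-bonded chain carbon. For the measured compounds named here, whether this change alone moves the number cannot be read from any measured pair, since no step between two measured compounds is available. Going by the values given here, the only guide is compound 1, whose value of 12000 nM shows that a compound of this series can sit well below compound 2. An improvement from compound 2 to compound 3 is therefore expected, by a 5.1-fold lower number from compound 2 to compound 3 (0.71 log units; beyond the scatter), a step likely beyond the scatter. For compound 3 the estimate is 15000 nM, within a range from 5000 nM to 45000 nM.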

Compound 3, concentration for 50% growth inhibition: 14000 nM
Compound 3: the middle estimate sits 1.1-fold (0.03 log units) above what was measured, and the stated range covers the measured number.
By their numbers in this assay, from the lowest: compounds 1 and 3 (each within the scatter of the next); then compound 2.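

In this assay, the place on a double-bonded chain carbon bound to a double-bonded chain carbon now has its first direct reading: putting 2-bromophenyl in place of pentan-3-yl gives a 5.5-fold lower number from compound 2 to compound 3 (0.74 log units; beyond the scatter). For the compounds shown here, the earlier compounds offered no pair that differed in one place, so this is the first sign that the group held here matters for growth inhibition on this read-out. The change swaps an open carbon chain with no ring for a six-membered aromatic ring carrying bromine, and the gain in the number belongs to that swap as a whole; nothing available explains why the number moves.

What the compounds shown leave open is which part of the new group carries the step, the aromatic ring itself or the bromine on it, since the two enter together. A plain phenyl or a cyclohexyl group at this place, or 2-chlorophenyl in place of 2-bromophenyl, would separate these parts, and a longer chain would show whether an open chain can do as well.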